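Adding an Amino Group to a Short-Lived Compound

The compounds below may be only part of what the source reports. "The series", "measured", "known", "first", "only" and "open" are said of these compounds alone.

Compound 1 `Nc1ncnc2c1c(Oc1cc(C(F)(F)F)ccn1)nn2C1CCCC1` was tested in an ADME assay on microsomes from liver (Homo sapiens) for metabolic stability, read by LC-MS, using NADPH, with a stated time of 10 min, tested at 10 uM (on this read-out higher numbers stand for a longer-lived compound and lower numbers for a shorter-lived compound), where compound 1 gives 0.333 h. That is the lowest of the three numbers recorded here. Compound 2 `CC(C)(C)n1nc(Oc2cc(Cl)ccn2)c2c(N)ncnc21` gives 1 h in this assay, and compound 3 `Nc1ncnc2c1c(Oc1cc(O)ccn1)nn2[C@H]1C[C@H](F)C1` gives 1.03 h; both gaps from compound 1 lie beyond the usual scatter. Compound 4 `Nc1ncnc2c1c(Oc1cc(C(F)(F)F)ccn1)nn2[C@@H]1CC[C@H](N)C1` has not yet been measured. It differs from compound 1 in one place: amino in place of hydrogen on a saturated ring carbon. For the measured compounds named here, no two measured compounds differ from each other in just one place, so no measured step guides the expectation. In this assay the change is expected to be a 1.5-fold higher number from compound 1 to compound 4 (0.18 log units; within the scatter), small and of uncertain direction, likely within the scatter. Compound 4 is estimated at 0.5 h, with a range from 0.2 h to 1.2 h.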

Compound 4, half-life: > 2.41 h
Compound 4 gave a limit, no number; the forecaster's own chance of this, stated with the estimate: 5%; middle value at least 4.8-fold (0.68 log units) from the limit.
By their numbers in this assay, from the lowest: compound 1; then compounds 2 and 3 (each within the scatter of the next). At a limit, above all of these: compound 4.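

Cut one bond further out, the change is cyclopentyl to 3-aminocyclopentyl, and in this assay it gives an at least 7.2-fold higher number from compound 1 to compound 4 (0.85 log units; beyond the scatter). Compound 4 gives > 2.41 h, which is a limit and not a number, so the step has a floor but no full size. For the compounds shown here, the earlier compounds offered no single-place step, so this is the first sign that this saturated ring carbon can move the half-life beyond the scatter.

From the compounds shown here alone, whether a hydroxyl or a methylamino group on the same carbon would do the same stays open. So does whether the amino group would have this effect on a core carrying a tert-butyl group instead of the cyclopentyl ring.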